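This account rests on a few compounds, and the source may have more. Where it says the series, first, only, none or still open, it means among the compounds named here.

Measured compounds in an ADME assay on Vero cells (Chlorocebus sabaeus) for cytotoxicity, read by MTT assay, with a stated time of 72 h; a lower number here means that less compound is tolerated, a higher number that more compound is tolerated:

Compound 1, `O[C@@H]1Cc2ccccc2N[C@H](c2ccc(Cl)cc2)C1`, gives a limit of the assay, > 300000 nM.
Compound 2, `O[C@@H]1Cc2cc(Cl)ccc2N[C@H](c2ccc(Cl)cc2)C1`, gives 76600 nM.
Compound 3, `O[C@@H]1Cc2ccccc2N[C@H](c2ccccc2Cl)C1`, gives a limit of the assay, > 300000 nM.

The one fully counted step among these is an at least 3.9-fold lower number from compound 1 to compound 2 (0.59 log units; beyond the scatter), which follows from chloro in place of hydrogen on an aromatic carbon. The size of that step rests on (the limit of > 300000 nM in this assay, at which 2 of the 3 values shown sit), so it is known only as a lower bound on the change.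

Compound 3 carries the same atoms as compound 1 joined differently; the difference between the two cores is not broken down here. Compound 4, `O[C@@H]1Cc2ccccc2N[C@H](c2c(Cl)cccc2Cl)C1`, has not yet been measured in this assay. It differs from compound 3 by chloro in place of hydrogen on an aromatic carbon. Among the compounds with values here, this is the same kind of change as the one from compound 1 to compound 2, but not the same: there the chloro enters on a ring that is part of a fused system, meta and para to a fused ring, whereas here it enters on a six-membered ring of carbon only, ortho to a large group and meta to a chloro group.

For compound 4, a step of an at least 1.6-fold lower number from compound 3 to compound 4 (0.22 log units; that floor lies within the scatter) is expected, with the number for compound 4 estimated at 180000 nM and likely to fall between 60000 nM and 300000 nM. This expectation rests on the step from compound 1 to compound 2, an at least 3.9-fold lower number from compound 1 to compound 2 (0.59 log units; beyond the scatter), which was at least modest, tempered by the fact that compound 3 sits at the limit described in the limit of > 300000 nM in this assay, at which 2 of the 3 values shown sit, and the place of the change is not the same.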

Compound 4, half-maximal cytotoxic concentration: > 300000 nM
Compound 4 was reported as a limit; the forecaster's own chance of this, stated with the estimate: 50%; at least 1.6-fold (0.22 log units) between middle value and limit.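

In this assay compound 4 gives > 300000 nM, which is a limit of the assay. Compound 3 stands at that same limit, so no step can be read between compound 3 and compound 4: the limit of > 300000 nM in this assay, at which 3 of the 4 values shown sit. The compounds shown leave open whether chloro in place of hydrogen on this six-membered aromatic ring of carbon only changes the number at all, and by how much.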